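Swapping ethoxycarbonyl for hydrogen in compound 2

The compounds below may be only part of what the source reports. "The series", "measured", "known", "first", "only" and "open" are said of these compounds alone.

Values in a functional assay on microsomes from liver (Rattus norvegicus) for inhibition, read by spectrophotometry, with a stated time of 45 min (on this read-out higher numbers stand for weaker inhibition and lower numbers for stronger inhibition), for the compounds in this series:
- Compound 1 `CCOC(=O)C(CS)NC(=O)c1cc(C(C)(C)C)c(O)c(C(C)(C)C)c1` gives 200000 nM
- Compound 2 `CCOC(=O)C(CS)NC(=O)/C=C/c1cc(C(C)(C)C)c(O)c(C(C)(C)C)c1` gives 40000 nM
- Compound 3 `CC(C)(C)c1cc(C(=O)NCCS)cc(C(C)(C)C)c1O` gives 45000 nM
- Compound 4 `CC(C)(C)c1cc(/C=C/C(=O)NCCS)cc(C(C)(C)C)c1O` has no measurement yet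

Compound 2 (40000 nM) and compound 3 (45000 nM) lie within the usual scatter of each other, and both numbers fall clearly under that of compound 1 (200000 nM).

The next step turns compound 2 into compound 4 through one structural change hydrogen in place of ethoxycarbonyl on a saturated chain carbon bound to an amide-type nitrogen and a saturated chain carbon that puts hydrogen in place of ethoxycarbonyl on a saturated chain carbon bound to an amide-type nitrogen and a saturated chain carbon. Put another way, 1-(ethoxycarbonyl)-2-sulfanylethyl becomes 2-sulfanylethyl.

Going by the values given here, one measured step bears on this. The same exchange, in the same place but on a different core, gave a 4.4-fold lower number from compound 1 to compound 3 (0.65 log units; beyond the scatter) and that counts as modest yet beyond the scatter. A single pair is thin support, and nothing yet shows that the effect carries over from one core to the other. Even so, a similar drop is expected in this assay and is estimated as a 3.3-fold lower number from compound 2 to compound 4 (0.52 log units; beyond the scatter) for this step. For compound 4 the expected value is 12000 nM with an estimated range from 4000 nM to 40000 nM in this assay.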

Compound 4, half-maximal inhibitory concentration: 30000 nM
Compound 4: middle estimate off by 2.5-fold (0.40 log units), on the low side; the range from low to high includes it.
By their numbers in this assay, from the lowest: compounds 4, 2 and 3 (each within the scatter of the next); then compound 1.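

In this assay, putting hydrogen in place of ethoxycarbonyl on this saturated chain carbon gives a 1.3-fold lower number from compound 2 to compound 4 (0.12 log units; within the scatter), so on the core of compound 2 the exchange leaves no change that can be told from the scatter. With only compound 1 and compound 3 to go on, the exchange could be read as a general gain in inhibition, but the second pair shows that the size of the step differs with the core that carries it: the same change on two cores in this assay, a 4.4-fold lower number (0.65 log units; beyond the scatter) from compound 1 to compound 3 and a 1.3-fold lower number (0.12 log units; within the scatter) from compound 2 to compound 4, 3.3-fold (0.52 log units) apart, beyond the scatter of two such steps Taking ethoxycarbonyl away thus gives a step beyond the scatter only on the core of compound 1, and the pair starting at compound 2 goes against any general rule for this position.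

The compounds shown carry only ethoxycarbonyl or hydrogen at this position, so it remains open how a carboxylic acid, a methoxycarbonyl group or an amine would read there on either core. Two pairs also cannot tell which feature of the cores sets the size of the step, and that question would need further pairs on other cores.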